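A Methyl Shift Across Two Related Cores

A few compounds are considered here, and "the series" means these few. Any claim that something is new, unique, unknown or untested is made for them only; others in the source may bear on it.

Compound 1 `Cc1nn2c(-c3nc4cc(Cl)ccc4[nH]3)c(-c3ccccc3)nc2s1` gives 16900 nM in a functional assay on A549 cells (Homo sapiens) for antiproliferative activity, read by MTT assay; on this read-out higher numbers stand for weaker inhibition and lower numbers for stronger inhibition. Compound 3 `Cc1ccc(-c2nc3sc(C)nn3c2-c2nc3cc(Cl)ccc3[nH]2)cc1` differs from it by one group: methyl in place of hydrogen on an aromatic carbon and in this assay compound 3 gives 4400 nM, so a 3.8-fold lower number from compound 1 to compound 3 (0.58 log units; beyond the scatter). Compound 2 `Cc1ccc2[nH]c(-c3c(-c4ccc(F)cc4)nc4sc(C)nn34)nc2c1` rests on a different core, and how the two cores differ is not broken down here; in this assay compound 2 gives 11700 nM. Compound 4 `Cc1nn2c(-c3nc4cc(C)c(C)cc4[nH]3)c(-c3ccc(F)cc3)nc2s1` is not yet measured; it carries methyl in place of hydrogen on an aromatic carbon. This is the same kind of change as from compound 1 to compound 3, but the place differs: here the methyl enters a ring that is part of a fused or bridged system of two rings, ortho to a methyl group, rather than a position para to a large group. Because a 3.8-fold lower number from compound 1 to compound 3 (0.58 log units; beyond the scatter) was only modest and the surroundings differ, the step from compound 2 to compound 4 is expected to be smaller, a 1.7-fold lower number from compound 2 to compound 4 (0.22 log units; within the scatter). Compound 4 is therefore estimated at 7000 nM, between 3000 nM and 16000 nM.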

Compound 4, half-maximal inhibitory concentration: > 30000 nM
Compound 4 gave a limit, no number (the forecaster's own chance of this, stated with the estimate: 5%); middle value at least 4.2-fold (0.63 log units) away from the limit.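

In this assay, on these data alone, methyl in place of hydrogen on an aromatic carbon gives an at least 2.5-fold higher number from compound 2 to compound 4 (0.40 log units; beyond the scatter), opposite in direction to the earlier step, so the same change did not carry over from one core to the other: the same change on two cores in this assay, a 3.8-fold lower number (0.58 log units; beyond the scatter) from compound 1 to compound 3 and an at least 2.5-fold higher number (0.40 log units; beyond the scatter) from compound 2 to compound 4, at least 9.8-fold (0.99 log units) apart, beyond the scatter of two such steps Compound 4 gives > 30000 nM, which is a limit of the assay and not a number, so the true size of its step stays unknown. The methyl also enters at a different place in each pair, so these two pairs alone do not show whether the core or the place decides the outcome.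

The compounds shown leave open how either core would respond to the same methyl at the other place. They also leave open what an amine or a longer chain would do there.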